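The source may hold more compounds than are shown below. What is called first, only, known or untested is meant among the compounds shown, and "the series" means these compounds.

Measured in a functional assay on IMR-32 cells with melanin-concentrating hormone receptor 1 (Homo sapiens) as the target, read by fluorescence; a higher number here means a weaker inhibitor, a lower number a stronger inhibitor:
compound 1, `CC(CNCC1CCCC1)Oc1cccc2ccc(N)nc12`, 100 nM
compound 2, `CC(CNC1CC1)Oc1cccc2ccc(N)nc12`, 580 nM
compound 3, `CC(CNC1CCCC1)Oc1cccc2ccc(N)nc12`, 30 nM

Compound 3 holds the lowest number of the three in this assay: one gap is a 3.3-fold lower number from compound 1 to compound 3 (0.52 log units; beyond the scatter), and the other is a 19-fold lower number from compound 2 to compound 3 (1.29 log units; beyond the scatter). Compound 4, `CC(CNCc1ccccc1)Oc1cccc2ccc(N)nc12`, has not been measured. The change from compound 3 is benzyl in place of cyclopentyl on an amine nitrogen. For the measured compounds named here, the steps that bear on it are the two already seen on the same amine nitrogen, a 3.3-fold lower number from compound 1 to compound 3 (0.52 log units; beyond the scatter) and a 19-fold lower number from compound 2 to compound 3 (1.29 log units; beyond the scatter). Of the groups measured there, cyclopentylmethyl is the closest counterpart to benzyl, so compound 4 is expected to move back toward the number of compound 1, a modest step upward, a 3.3-fold higher number from compound 3 to compound 4 (0.52 log units; beyond the scatter). Compound 4 is therefore estimated at 100 nM, with a range from 35 nM to 300 nM.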

Compound 4, half-maximal inhibitory concentration: 340 nM
Compound 4: middle estimate off by 3.4-fold (0.53 log units), on the low side; the measured number lies above the stated range.
By their numbers in this assay, from the lowest: compound 3; then compound 1; then compounds 4 and 2 (each within the scatter of the next).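

In this assay phenyl in place of cyclopentyl on a saturated chain carbon bound to an amine nitrogen gives a 3.4-fold higher number from compound 1 to compound 4 (0.53 log units; beyond the scatter) and shows that the aromatic ring cannot stand in for the five-membered non-aromatic ring here. Benzyl in place of cyclopentyl gives an 11-fold higher number from compound 3 to compound 4 (1.05 log units; beyond the scatter) while benzyl in place of cyclopropyl gives a 1.7-fold lower number from compound 2 to compound 4 (0.23 log units; within the scatter) and so leaves these two groups indistinguishable at this nitrogen. Nothing measured here explains the difference between the rings. Going by these compounds, whether cyclohexyl on the nitrogen would hold the number of compound 3 remains open, as does whether a pyridine ring or a longer chain such as phenethyl would recover anything from benzyl.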